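The source may report more compounds than this note shows. Statements on the series, on what has been measured and on what is new or still open speak of the compounds shown alone.

Working notes on the halogen series, starting from compound 1 `C#C[C@@]1(O)[C@@H](CO)O[C@@H](n2cc(Cl)c3c(Cl)ccnc32)[C@@H]1O`. For the measured compounds named here, in a functional assay on CCRF-CEM cells (Homo sapiens) for antiproliferative activity, read by cell counting, with a stated time of 72 h (on this read-out lower numbers stand for stronger inhibition and higher numbers for weaker inhibition), compound 1 gives 1300 nM, while compound 2 `C#C[C@@]1(O)[C@@H](CO)O[C@@H](n2cc(Br)c3c(Cl)ccnc32)[C@@H]1O` gives 560 nM, the lowest of the two numbers so far and the only one below its neighbour. Compound 3 `C#C[C@@]1(O)[C@@H](CO)O[C@@H](n2cc(I)c3c(Cl)ccnc32)[C@@H]1O` is the next member, still unmeasured. Its change from compound 2 is iodo in place of bromo on an aromatic carbon of the five-membered aromatic ring. Going by the values given here, only one measured step bears on this: a 2.3-fold lower number from compound 1 to compound 2 (0.37 log units; beyond the scatter), a modest move beyond the scatter, for bromo in place of chloro on the same kind of carbon. One step gives a direction but no trend, and the data do not show whether it carries on to iodo. In this assay the expectation is therefore a further modest step towards a lower number, of about the size seen for compound 2 in a 2.3-fold lower number from compound 1 to compound 2 (0.37 log units; beyond the scatter) or smaller, and a result within the scatter would not be surprising. The expected step is a 1.7-fold lower number from compound 2 to compound 3 (0.23 log units; within the scatter). For compound 3 the estimated value is 330 nM, with an expected range of 140 nM to 750 nM.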

Compound 3, half-maximal inhibitory concentration: 260 nM
The estimate for compound 3 lay 1.3-fold (0.10 log units) above the measured number; the range from low to high includes it.
By their numbers in this assay, from the lowest: compound 3; then compound 2; then compound 1.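

In this assay, the change from bromo to iodo continues in the direction set by the change from chloro to bromo, with a 2.2-fold lower number from compound 2 to compound 3 (0.33 log units; beyond the scatter), so this position now offers two steps the same way rather than one. Taken end to end on this aromatic carbon of the five-membered aromatic ring, the series shows a 5.0-fold lower number from compound 1 to compound 3 (0.70 log units; beyond the scatter), and the order chloro, bromo, iodo holds across all three compounds, with none going against it. Nothing at hand accounts for this order, so it stands as an observation on these three compounds only.

The compounds shown are all halogen analogues at this carbon, which leaves open whether the order says anything about other groups there, such as fluoro, methyl, a nitrile or an amine. The second chloro on the shared core and the sugar-like ring with its ethynyl and hydroxyl groups are the same in all three compounds, so these results cannot show whether the halogen order would hold with a different group at either place.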